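A Larger Group on the Amide Carbonyl

The source may hold more compounds than are shown below. What is called first, only, known or untested is meant among the compounds shown, and "the series" means these compounds.

Compound 1 `Cn1cc(-c2cnc3ccc(NC(=O)C4CC4)nc3c2)cn1`: > 50000 nM
Compound 2 `Cn1cc(-c2cnc3ccc(NCC4CC4)nc3c2)cn1`: > 50000 nM
Compound 3 `CC(=O)Nc1nccc2ncc(-c3cnn(C)c3)cc12`: > 50000 nM

All three compounds were tested in a functional assay on HeLa cells (Homo sapiens) for antiproliferative activity, read by MTT assay, with a stated time of 48 h (on this read-out higher numbers stand for weaker inhibition and lower numbers for stronger inhibition), and none of the three results is an exact number. In this assay compound 3 gives > 50000 nM, which is a limit of the assay. It therefore has no measured potency from which to count a change. Within the data shown here, the whole series so far stands at the limit of > 50000 nM in this assay, at which 3 of the 3 values shown sit.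

Compound 4 `COc1ccc(C(=O)Nc2nccc3ncc(-c4cnn(C)c4)cc23)cc1` keeps the core of compound 3 and carries 4-methoxyphenyl in place of methyl on a carbonyl carbon.

Among the measured compounds shown here, the only measured step is a step that the two limits leave unreadable from compound 1 to compound 2. It involves a different change and offers no size to carry over, so the data do not fix the size of the next step. Any readable change in this assay could only be towards stronger inhibition, and a modest one at best is expected. This expectation rests on compound 1, compound 2 and compound 3, which all share (the limit of > 50000 nM in this assay, at which 3 of the 3 values shown sit). A result at the same limit would be no surprise.

The expected change is an at least 1.6-fold lower number from compound 3 to compound 4 (0.22 log units; that floor lies within the scatter). For compound 4 the estimate is 30000 nM, with an expected range from 8000 nM to 60000 nM.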

Compound 4, half-maximal inhibitory concentration: > 50000 nM
Compound 4 ended at the assay's limit; the forecaster's own chance of this, stated with the estimate: 55%; middle value at least 1.6-fold (0.22 log units) from the limit.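

Compound 3 and compound 4 both stand at a limit of this assay rather than at a number, so the change from methyl to 4-methoxyphenyl on the carbonyl carbon has no readable size. The series stays where it was: the limit of > 50000 nM in this assay, at which 4 of the 4 values shown sit.

The compounds shown leave open which structural change, if any, would give a measurable number in this assay.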